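Methylamino in place of methyl: expectation for compound 4

This account rests on a few compounds, and the source may have more. Where it says the series, first, only, none or still open, it means among the compounds named here.

For the measured compounds named here, compound 1 `Cc1ccc(Nc2ncc3c(n2)N(C)C(=O)N(c2cc(NC(=O)c4cccc(C(F)(F)F)c4)ccc2C)C3)cc1C` is the only member of the set with a number in an ADME assay on BaF3 cells (Mus musculus) for antiproliferative activity, read by CellTiter-Glo and CCK-8 assay, with a stated time of 72 h; a higher number here means a weaker inhibitor of growth, a lower number a stronger inhibitor of growth: compound 1 gives 3760 nM. Compound 2 `Cc1ccc(NC(=O)c2cccc(C(F)(F)F)c2)cc1N1Cc2cnc(Nc3ccc(C)c(C(F)(F)F)c3)nc2N(C)C1=O` reaches only a limit, > 10000 nM. Compound 3 `Cc1ccc(NC(=O)c2cccc(C(F)(F)F)c2)cc1N1Cc2cnc(OC3CCN(C(=O)OC(C)(C)C)CC3)nc2N(C)C1=O` likewise sits at a limit, > 10000 nM. Going by the values given here, the single measured step, an at least 2.6-fold higher number from compound 1 to compound 2 (0.42 log units; beyond the scatter), ends at the limit of > 10000 nM in this assay, at which 2 of the 3 values shown sit, which hides its true size. Compound 4 `CNc1cc(Nc2ncc3c(n2)N(C)C(=O)N(c2cc(NC(=O)c4cccc(C(F)(F)F)c4)ccc2C)C3)ccc1C` differs from compound 1 by methylamino in place of methyl on an aromatic carbon. Among the compounds with values here, the step from compound 1 to compound 2 changes the same aromatic carbon and gave a weaker number; methylamino is a different group, and no measured pair tests it. For compound 4 the expected step is a 1.2-fold higher number from compound 1 to compound 4 (0.08 log units; within the scatter), within the scatter. Compound 4 is estimated at 4500 nM, between 1500 nM and 13000 nM.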

Compound 4, concentration for 50% growth inhibition: > 10000 nM
Compound 4 gave a limit, no number; the forecaster's own chance of this, stated with the estimate: 30%; at least 2.2-fold (0.34 log units) between middle value and limit.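

In this assay the step for methylamino in place of methyl is an at least 2.6-fold higher number from compound 1 to compound 4 (0.42 log units; beyond the scatter) and so a second replacement of this methyl, after trifluoromethyl, also weakens growth inhibition. Of the three groups shown on this aromatic carbon, only methyl gives a number, since compound 4 stands at a limit. The step between compound 2 and compound 4 cannot be read, and the full size of the loss stays hidden: the limit of > 10000 nM in this assay, at which 3 of the 4 values shown sit.

As far as these compounds go, whether any other group on this carbon can match methyl remains open. A primary amine, a hydroxyl or a fluorine atom here would test this.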